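A few compounds are considered here, and "the series" means these few. Any claim that something is new, unique, unknown or untested is made for them only; others in the source may bear on it.

Measured so far in a functional assay on PC-3 cells (Homo sapiens), read by MTT assay, with a stated time of 48 h; a higher number here means a weaker inhibitor, a lower number a stronger inhibitor:
- compound 1 `CCn1c(C(=O)NCCN(C)C)ccc1C(CC)(CC)c1ccc(OCC(=O)C(C)(C)C)c(C)c1`: 2300 nM
- compound 2 `CCn1c(C(=O)NCCN(C)C)ccc1C(CC)(CC)c1ccc(OCC(O)C(C)(C)C)c(C)c1`: 1630 nM
- compound 3 `C#CC(C)OC(=O)c1ccc(C(CC)(CC)c2ccc(OCC(O)C(C)(C)C)c(C)c2)n1CC`: 38200 nM

Compound 1 sits with compound 2 at the low end of these numbers, and the two cannot be separated: a 1.4-fold lower number from compound 1 to compound 2 (0.15 log units; within the scatter). Compound 3 stands well apart from that pair at 38200 nM.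

The next compound to be measured is compound 4 `CCn1c(C(=O)N(C)CC(=O)O)ccc1C(CC)(CC)c1ccc(OCC(=O)C(C)(C)C)c(C)c1`, which keeps the core of compound 1 and alters only the amide side chain: (carboxymethyl)(methyl)amino in place of (2-(dimethylamino)ethyl)amino on a carbonyl carbon. In short, (carboxymethyl)(methyl)amino stands in place of (2-(dimethylamino)ethyl)amino on a carbonyl carbon.

One measured step removes the same group from the same place: a 23-fold higher number from compound 2 to compound 3 (1.37 log units; beyond the scatter). That step is large, but it brings in (1-methylprop-2-yn-1-yl)oxy, a different group, and starts from compound 2, so it is only a partial guide. The step of a 1.4-fold lower number from compound 1 to compound 2 (0.15 log units; within the scatter) lies elsewhere in the molecule and gives no direct reading on this change. Based on compound 3 at 38200 nM, a clear move to a higher number is expected in this assay, probably somewhat smaller than that single precedent.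

The expected result is an 8.7-fold higher number from compound 1 to compound 4 (0.94 log units; beyond the scatter).

The estimate for compound 4 is 20000 nM, with an expected range of 6000 nM to 60000 nM.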

Compound 4, half-maximal inhibitory concentration: 18400 nM
The estimate for compound 4 lay 1.1-fold (0.04 log units) above the measured number; the measured number falls inside the stated range.
By their numbers in this assay, from the lowest: compounds 2 and 1 (each within the scatter of the next); then compound 4; then compound 3.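

In this assay, the replacement of (2-(dimethylamino)ethyl)amino on a carbonyl carbon now has a reading on the core of compound 1 itself, where (carboxymethyl)(methyl)amino gives a clear rise (an 8.0-fold higher number from compound 1 to compound 4 (0.90 log units; beyond the scatter)). The only earlier reading at this place started from a different compound and brought in (1-methylprop-2-yn-1-yl)oxy (a 23-fold higher number from compound 2 to compound 3 (1.37 log units; beyond the scatter)); both replacements shown at this position therefore give a higher number, and no compound shown goes against this. The new group keeps the amide and has the same 6 heavy atoms as the group it replaces, so the rise comes without a change in that count, although the atoms differ: one nitrogen fewer, one carbon fewer and two oxygens more. No measurement is at hand that accounts for the rise.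

Still open, from the compounds shown here alone, is whether the rise follows the loss of the dimethylamino group or the entry of the carboxylic acid; a (2-hydroxyethyl)amino or a (3-(dimethylamino)propyl)amino side chain on the same core would help separate the two. Also open, going by these compounds, is how the carboxylic acid side chain reads on the core of compound 2, which carries the hydroxyl in place of the ketone.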